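The source may report more compounds than this note shows. Statements on the series, on what has been measured and on what is new or still open speak of the compounds shown alone.

Compound 1 `CC1CCN(C2CCN(S(=O)(=O)c3cnc(Cl)s3)CC2)CC1` was tested in an ADME assay on HCT-116 cells (Homo sapiens) for cytotoxicity, read by CellTiter-Glo, with a stated time of 72 h; a higher number here means a weaker inhibitor, a lower number a stronger inhibitor. In this assay compound 1 gives > 10000 nM, which is a limit of the measurement rather than a number. Compound 1 therefore stands at the limit of > 10000 nM in this assay, at which 1 of the 3 values shown sits. Two other compounds sit at a second limit, (the limit of > 5000 nM in this assay, at which 2 of the 3 values shown sit). Compound 2 `Cc1cc(C)c(S(=O)(=O)c2ccc(N3CCC(C)CC3)cc2)c(C)c1` gives > 5000 nM in this assay, again a limit. Compound 3 `COc1ccc(NS(=O)(=O)N2CCC(N3CCC(C)CC3)CC2)cc1` gives > 5000 nM in this assay, also a limit. Among the measured compounds shown here, none of the three compounds has a measured number, so no step between measured compounds can be drawn from them.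

Compound 4 `COc1cccc(S(=O)(=O)N2CCC(N3CCC(C)CC3)CC2)c1` has not yet been measured. It differs from compound 1 in one place: 3-methoxyphenyl in place of 2-chloro-1,3-thiazol-5-yl on a sulfonyl sulfur. For the measured compounds named here, with no measured step to lean on, the expectation for compound 4 rests only on the three limits, and the step that the limit leaves unreadable from compound 1 to compound 4 is expected to be none beyond the scatter. Compound 4 is expected to give about 15000 nM in this assay, within a range from 5000 nM to 50000 nM, and most likely to come back as a limit again rather than as a number.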

Compound 4, half-maximal inhibitory concentration: > 5000 nM
Compound 4: a limit, no number; the forecaster's own chance of this, stated with the estimate: 85%; the middle value does not contradict the limit.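

Compound 1 and compound 4 each return only a limit in this assay, not a number, so the step between them cannot be read. The compounds shown leave open whether any group on the sulfonyl sulfur can give a measurable number in this assay.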